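The source may hold more compounds than are shown below. What is called first, only, known or untested is meant among the compounds shown, and "the series" means these compounds.

Measured in a physicochemical assay for solubility, read by nephelometry, measured as kinetic solubility, with a stated time of 30 min; on this read-out lower numbers stand for lower solubility and higher numbers for higher solubility:
- compound 1 `CC(C)(O)CN1CCC(Oc2ccc([C@H]3CC[C@]4(CC3)OOC3(O4)C4CC5CC(C4)CC3C5)cc2)CC1`: 1.6 ug/mL
- compound 2 `CC(C)(N)CCOc1ccc([C@H]2CC[C@]3(CC2)OOC2(O3)C3CC4CC(C3)CC2C4)cc1`: 50 ug/mL
- compound 3 `c1cc([C@H]2CC[C@]3(CC2)OOC2(O3)C3CC4CC(C3)CC2C4)ccc1OC1CCNCC1`: > 100 ug/mL ( a limit, not a number )

Compound 3 stands at the limit of > 100 ug/mL in this assay, at which 1 of the 3 values shown sits, so its true position is not known. The step of an at least 2.0-fold higher number from compound 2 to compound 3 (0.30 log units; that floor lies within the scatter) does not separate it from its nearest neighbour, whereas the step of an at least 62-fold higher number from compound 1 to compound 3 (1.79 log units; beyond the scatter) is large.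

Compound 4 `CC(C)(CN)Oc1ccc([C@H]2CC[C@]3(CC2)OOC2(O3)C3CC4CC(C3)CC2C4)cc1` carries 1-(aminomethyl)-1-methylethyl in place of piperidin-4-yl on an oxygen on an aromatic ring.

Going by the values given here, no measured step makes this exact change. The closest guide is the step of an at least 2.0-fold higher number from compound 2 to compound 3 (0.30 log units; that floor lies within the scatter), where a side chain with no ring also replaces piperidin-4-yl. The large step of a 31-fold higher number from compound 1 to compound 2 (1.49 log units; beyond the scatter) bears only indirectly, since compound 4 lacks the 2-hydroxy-2-methylpropyl group, as do the two higher compounds. In this assay a small step toward lower numbers is therefore expected, probably not beyond the scatter.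

The expected change is an at least 1.6-fold lower number from compound 3 to compound 4 (0.22 log units; that floor lies within the scatter).

For compound 4 the estimated value is 60 ug/mL, with an expected range from 20 ug/mL to 120 ug/mL.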

Compound 4, solubility: > 100 ug/mL
Compound 4 ended at the assay's limit; the forecaster's own chance of this, stated with the estimate: 30%; middle value at least 1.6-fold (0.22 log units) away from the limit.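

In this assay compound 4 gives > 100 ug/mL, which is a limit and not a number. The oxygen on the aromatic ring can thus carry a group with no ring, 1-(aminomethyl)-1-methylethyl, and still read at the same limit as the piperidin-4-yl of compound 3, with an at least 2.0-fold higher number from compound 2 to compound 4 (0.30 log units; that floor lies within the scatter) and an at least 62-fold higher number from compound 1 to compound 4 (1.79 log units; beyond the scatter). The step between the two compounds at the limit cannot be read, so neither can be placed ahead of the other: the limit of > 100 ug/mL in this assay, at which 2 of the 4 values shown sit.

Going by these compounds, how far compound 3 and compound 4 truly lie past that limit stays open. Also open, on these data alone, is how this assay would read if a carboxylic acid or a hydroxyl took the place of the amine in 1-(aminomethyl)-1-methylethyl, and so whether the amine matters at this position.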